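Swapping 4-nitrophenyl for pyridin-2-yl in compound 3

This account rests on a few compounds, and the source may have more. Where it says the series, first, only, none or still open, it means among the compounds named here.

In a functional assay on MDA-MB-231 cells (Homo sapiens) for antiproliferative activity, with a stated time of 4 days (a higher number here means a weaker inhibitor, a lower number a stronger inhibitor), compound 3 `CCCCc1ccc2[nH]c(-c3ccc(C(F)(F)F)cc3)c(/C=N/NC(=O)c3ccc([N+](=O)[O-])cc3)c2c1` gives 2040 nM, the highest number of the three measured. Compound 1 `CCCCc1ccc2[nH]c(-c3ccc(C(F)(F)F)cc3)c(/C=N/NC(=O)c3ccccc3)c2c1` gives 300 nM, and compound 2 `CCCCc1ccc2[nH]c(-c3ccc(OC)cc3)c(/C=N/NC(=O)c3ccc([N+](=O)[O-])cc3)c2c1` gives 115 nM. Compound 4 `CCCCc1ccc2[nH]c(-c3ccc(C(F)(F)F)cc3)c(/C=N/NC(=O)c3ccccn3)c2c1` carries pyridin-2-yl in place of 4-nitrophenyl on a carbonyl carbon. The closest evidence is the modest 6.8-fold higher number from compound 1 to compound 3 (0.83 log units; beyond the scatter), seen with nitro in place of hydrogen on an aromatic carbon. The large 18-fold higher number from compound 2 to compound 3 (1.25 log units; beyond the scatter) concerns trifluoromethyl in place of methoxy, so it bears only on the standing of compound 3. For the measured compounds named here, no pyridin-2-yl compound has been measured, so the expectation remains uncertain. A modest drop is expected, with an estimated 4.1-fold lower number from compound 3 to compound 4 (0.61 log units; beyond the scatter). Compound 4 is estimated at 500 nM, within a range of 150 nM to 1700 nM.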

Compound 4, half-maximal inhibitory concentration: 260 nM
Compound 4: middle estimate off by 1.9-fold (0.28 log units), on the high side; measured number inside the range.
By their numbers in this assay, from the lowest: compound 2; then compounds 4 and 1 (each within the scatter of the next); then compound 3.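

In this assay, pyridin-2-yl in place of 4-nitrophenyl on the carbonyl carbon gives a 7.8-fold lower number from compound 3 to compound 4 (0.89 log units; beyond the scatter), so the rise that came with the nitro group does not appear with this ring. Against phenyl, the same position gives a 1.2-fold lower number from compound 1 to compound 4 (0.06 log units; within the scatter), so the ring nitrogen leaves no readable change in this trifluoromethyl pair. No available measurement accounts for either step. On these data alone, whether pyridin-2-yl behaves the same alongside the methoxy group of compound 2 remains open. So does the effect of an aminophenyl or carboxyphenyl group on this carbonyl carbon.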